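This account rests on a few compounds, and the source may have more. Where it says the series, first, only, none or still open, it means among the compounds named here.

Three compounds of the shared core have been run in a functional assay on MGC-803 cells (Homo sapiens) for inhibition, read by sulforhodamine B assay; a lower number here means a stronger inhibitor, a higher number a weaker inhibitor. Compound 1 `CCOc1ccc(NC2=CC(=O)c3c(nc4n3[C@H]3OC[C@@H](O)[C@H]3OC4)C2=O)cc1` gives 2090 nM; compound 2 `CCc1ccc(NC2=CC(=O)c3nc4n(c3C2=O)[C@H]2OC[C@@H](O)[C@H]2OC4)cc1` gives 1290 nM; compound 3 `CCOc1ccccc1NC1=CC(=O)c2c(nc3n2[C@H]2OC[C@@H](O)[C@H]2OC3)C1=O` gives 2830 nM. Compound 2 has the lowest of the three numbers, but compound 1 sits within the scatter of it, and only compound 3 lies beyond the scatter from compound 2. Within the data shown here, the one single-point step among the measured compounds, a 1.4-fold higher number from compound 1 to compound 3 (0.13 log units; within the scatter), is small.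

Compound 4 `O=C1C=C(Nc2ccccc2F)C(=O)c2c1nc1n2[C@H]2OC[C@@H](O)[C@H]2OC1` is not yet measured in this assay. It differs from compound 2 in one place: 2-fluorophenyl in place of 4-ethylphenyl on an amine nitrogen. Among the measured compounds shown here, no measured pair carries fluorine on this aryl group, so the only step that bears on the change is the ethoxy move from compound 1 to compound 3, which stayed within the scatter; it speaks to the shift from the 4-position to the 2-position of the aryl group but not to the exchange of an ethyl for a fluorine. The expected outcome is therefore a number for compound 4 close to that of compound 2, with a modest move toward a higher number as the more likely direction, a 1.9-fold higher number from compound 2 to compound 4 (0.27 log units; within the scatter), and a wide range. The estimate for compound 4 in this assay is 2400 nM, between 1100 nM and 5500 nM.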

Compound 4, half-maximal inhibitory concentration: 2080 nM
The estimate for compound 4 lay 1.2-fold (0.06 log units) above the measured number; the measured number falls inside the stated range.
By their numbers in this assay, from the lowest: compounds 2, 4, 1 and 3 (each within the scatter of the next, the first and the last beyond it).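

In this assay, the step from the (4-ethylphenyl)amino group to the (2-fluorophenyl)amino group on the shared core is a 1.6-fold higher number from compound 2 to compound 4 (0.21 log units; within the scatter), so an exchange of the substituent itself, and not only a shift of its place as in a 1.4-fold higher number from compound 1 to compound 3 (0.13 log units; within the scatter), also stays within the scatter. The aryl group on this amine nitrogen can therefore lose the ethyl and carry a fluorine with no resolved effect on the number, which extends the earlier ethoxy result to a second, different kind of substituent. No evidence is available on why this exchange leaves the number within the scatter.

The step changes the substituent and its place on the aryl group together, so a 4-fluorophenyl group on the same amine nitrogen would be needed to separate the two. Also open is whether a carboxylic acid or an amine on the aryl group, or a longer alkoxy chain, would give a step beyond the scatter; both single-place steps shown lie within it.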